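Phenyl for methyl on the carbonyl carbon, two cores

The compounds below may be only part of what the source reports. "The series", "measured", "known", "first", "only" and "open" are said of these compounds alone.

Measured so far in an assay for inhibition of epoxide hydrolase 1 (Homo sapiens), read by fluorescence, using microsomes; a lower number here means a stronger inhibitor, a higher number a weaker inhibitor:
compound 1 `O=C(NC(=S)Nc1ccc(Oc2ccccc2)cc1)c1ccccc1` gives 2100 nM
compound 2 `CC(=O)NC(=S)Nc1ccc(Oc2ccccc2)cc1` gives 3700 nM
compound 3 `CC(=O)NC(=S)Nc1ccncc1` gives 2070 nM

Compound 4 `O=C(NC(=S)Nc1ccncc1)c1ccccc1` has not been measured. Compound 2 and compound 1 differ by one change, (phenyl in place of methyl on a carbonyl carbon), and the step is a 1.8-fold lower number from compound 2 to compound 1 (0.25 log units; within the scatter). The same change leads from compound 3 to compound 4: phenyl in place of methyl on a carbonyl carbon. The two cores, that of compound 2 and that of compound 3, differ in more than one place; the difference between them is not broken down here. Their values in this assay lie within the usual scatter of each other.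

For compound 4 a step of a 1.6-fold lower number from compound 3 to compound 4 (0.20 log units; within the scatter) is expected, resting on the step of a 1.8-fold lower number from compound 2 to compound 1 (0.25 log units; within the scatter) seen with the first core. Compound 4 is therefore estimated at 1300 nM, with a likely range of 500 nM to 3500 nM.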

Compound 4, half-maximal inhibitory concentration: 2280 nM
Compound 4: middle estimate off by 1.8-fold (0.24 log units), on the low side; low and high end bracket the measured number.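

In this assay, phenyl in place of methyl on a carbonyl carbon gives a 1.1-fold higher number from compound 3 to compound 4 (0.04 log units; within the scatter), so on this core the number stays within the scatter. Set beside the first core, the two steps do not separate: the same change on two cores in this assay, a 1.8-fold lower number (0.25 log units; within the scatter) from compound 2 to compound 1 and a 1.1-fold higher number (0.04 log units; within the scatter) from compound 3 to compound 4, 1.9-fold (0.29 log units) apart, within the scatter of two such steps. The change therefore carries from one core to the other without a detectable difference, but both steps lie within the scatter, so this shows neither a real effect of the change on either core nor that a larger effect would carry over.

Going by these compounds, whether an amine or a longer chain in place of methyl on the carbonyl carbon would give a step beyond the scatter stays open. The compounds shown hold this change on two cores only, so its behaviour on any other core is also open.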